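A few compounds are considered here, and "the series" means these few. Any claim that something is new, unique, unknown or untested is made for them only; others in the source may bear on it.

Measured in a functional assay on WI-38 VA13 cells (Homo sapiens) for cytotoxicity; a lower number here means that less compound is needed, a higher number that more compound is needed for the effect:
- compound 1 `CC(C)CC(=O)Nc1nc2ccc(NC(=O)c3c(Cl)cccc3Cl)cc2s1`: 0.012 ug/mL
- compound 2 `NCCC(=O)Nc1nc2ccc(NC(=O)c3c(Cl)cccc3Cl)cc2s1`: 5.3 ug/mL
- compound 3 `CCCOC(=O)Nc1nc2ccc(NC(=O)c3c(Cl)cccc3Cl)cc2s1`: 0.0025 ug/mL

Compound 3 has the lowest number of the three, so it needs the least compound for the effect. Compound 4 `CC(C)OC(=O)Nc1nc2ccc(NC(=O)c3c(Cl)cccc3Cl)cc2s1` differs from it in a single group: isopropyl in place of propyl on an oxygen next to a carbonyl group. In words, this is isopropyl in place of propyl on an oxygen next to a carbonyl group.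

Among the compounds with values here, no measured step isolates this swap, so the evidence is indirect. The closest comparison is a 4.8-fold lower number from compound 1 to compound 3 (0.68 log units; beyond the scatter), where the branched isobutyl gives way to propoxy. That step shows that a branched chain, in compound 1, still gives a low number. The far larger a 2100-fold lower number from compound 2 to compound 3 (3.33 log units; beyond the scatter) involves a 2-aminoethyl group, a very different replacement, and says little here. Since the same atoms are merely rearranged, only a small change is expected in this assay, with a slight rise more likely than a fall. The expected result is a 1.6-fold higher number from compound 3 to compound 4 (0.20 log units; within the scatter). For compound 4 the estimated value is 0.004 ug/mL, with an expected range of 0.0012 ug/mL to 0.014 ug/mL.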

Compound 4, half-maximal effective concentration: 0.0026 ug/mL
Compound 4: the middle estimate sits 1.5-fold (0.19 log units) above what was measured; low and high end bracket the measured number.
By their numbers in this assay, from the lowest: compounds 3 and 4 (each within the scatter of the next); then compound 1; then compound 2.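

Swapping propyl for isopropyl on an oxygen next to a carbonyl group makes no clear difference in this assay, with a 1.0-fold higher number from compound 3 to compound 4 (0.02 log units; within the scatter) within the scatter, so a branched chain serves here as well as a straight one. Compound 4 also stands well apart from the other two compounds, with a 4.6-fold lower number from compound 1 to compound 4 (0.66 log units; beyond the scatter) on replacing isobutyl and a 2000-fold lower number from compound 2 to compound 4 (3.31 log units; beyond the scatter) on replacing 2-aminoethyl, so the low number of compound 3 does not depend on its chain being straight. No supporting measurement is available to explain why this swap changes so little.

From the compounds shown here alone, whether a longer chain such as butyl or a bulkier one such as tert-butyl on this oxygen would keep the number as low remains open. So does whether an amine at the end of a propoxy chain would give a number as high as that of compound 2.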